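From carbamoyl to formyl: a small change at the limit

The source may report more compounds than this note shows. Statements on the series, on what has been measured and on what is new or still open speak of the compounds shown alone.

Measured in a toxicity assay on CCRF-CEM cells (Homo sapiens) for cytotoxicity; on this read-out lower numbers stand for higher toxicity in this test and higher numbers for lower toxicity in this test:
- Compound 1 `CC(=O)N(C)c1cccc2c1nc(-c1c(F)cccc1F)n2Cc1c(F)cccc1F` gives > 100 uM as a limit
- Compound 2 `NC(=O)c1cccc2c1nc(-c1c(F)cccc1F)n2Cc1c(F)cccc1F` gives > 100 uM as a limit

Compound 2 stands at > 100 uM in this assay and that is a limit, not a number. The whole record so far is the limit of > 100 uM in this assay, at which 2 of the 2 values shown sit, and nothing finer.

Compound 3 `O=Cc1cccc2c1nc(-c1c(F)cccc1F)n2Cc1c(F)cccc1F` alters one group: hydrogen in place of amino on a carbonyl carbon with hydrogen in place of amino on a carbonyl carbon, which turns carbamoyl into formyl.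

Going by the values given here, the one measured step is a step that the two limits leave unreadable from compound 1 to compound 2 and it offers no size to carry over. With only that to go on, the estimated change is a number no higher from compound 2 to compound 3 (the limit leaves the size open) and no step beyond the scatter is expected in this assay for this swap. For compound 3 the estimated value is 100 uM (expected range from 40 uM to 200 uM) and a report of only a limit would be no surprise.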

Compound 3, half-maximal toxic concentration: 0.82 uM
The estimate for compound 3 lay 120-fold (2.09 log units) above the measured number, and the stated range ends above it.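

In this assay, putting hydrogen in place of amino on the carbonyl carbon gives an at least 120-fold lower number from compound 2 to compound 3 (2.08 log units; beyond the scatter), so this one-atom swap at this position can move the read-out far beyond the scatter. Formyl in place of acetyl(methyl)amino on the aromatic carbon also gives an at least 120-fold lower number from compound 1 to compound 3 (2.08 log units; beyond the scatter), which sets compound 3 apart from both earlier compounds. Compound 3 is also the first compound here to give a true number rather than a limit: the limit of > 100 uM in this assay, at which 2 of the 3 values shown sit.

The compounds shown leave open whether this toxicity is specific to formyl or would also appear with another group on that aromatic carbon, such as acetyl, hydroxymethyl or a carboxylic acid. Going by these compounds, compound 1 and compound 2 are known only as limits: the full size of both steps remains open, and the step between those two cannot be read.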